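The source may report more compounds than this note shows. Statements on the series, on what has been measured and on what is new or still open speak of the compounds shown alone.

Working notes on the cytotoxicity series.

Three compounds have numbers in a functional assay on cells (Cancer cell lines, Homo sapiens) for cytotoxicity, with a stated time of 48 h; a lower number here means a stronger inhibitor of growth, a higher number a weaker inhibitor of growth. Compound 1 `COc1c(/C=C2/C(=O)Nc3ccccc32)c2ccccc2n1-c1ccccc1` gives 4470 nM in this assay, the lowest of the three numbers. Compound 3 `COc1cc2c(c(OC)c1OC)/C(=C\c1c(Cl)[nH]c3ccccc13)C(=O)N2` gives 8130 nM in this assay, and the gap between compound 1 and compound 3 lies within the usual scatter, so the two are not ordered. Compound 2 `COc1ccc2c(c1)/C(=C\c1c(Cl)n(C/C=C/c3ccccc3)c3ccccc13)C(=O)N2` gives 36300 nM in this assay, a gap from compound 1 that lies beyond the scatter. No pair among these three differs in a single place, so no isolated step between measured compounds is available.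

The compound not yet measured is compound 4 `COc1ccc2c(c1)/C(=C\c1c(OC)n(-c3ccccc3)c3ccccc13)C(=O)N2`. Relative to compound 1 the change is methoxy in place of hydrogen on an aromatic carbon of a six-membered aromatic ring of carbon only, part of a fused system of two rings, meta to a fused ring and para to a fused ring. Compound 2 and compound 3 each carry methoxy on that ring, but their other differences from compound 1 leave no clean read on the methoxy alone.

For compound 4 the expectation is a small step from compound 1 of size a 1.2-fold higher number from compound 1 to compound 4 (0.09 log units; within the scatter), not beyond the scatter in either direction. Compound 4 is therefore estimated at 5500 nM in this assay, with a range from 2000 nM to 15000 nM.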

Compound 4, concentration for total growth inhibition: 7240 nM
Beside the measured number, compound 4's estimate is 1.3-fold (0.12 log units) below it, and the stated range covers the measured number.
By their numbers in this assay, from the lowest: compounds 1, 4 and 3 (each within the scatter of the next); then compound 2.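

Among these compounds, compound 1 and compound 4 form the first pair that isolates a single change, and in this assay methoxy in place of hydrogen on an aromatic carbon gives a 1.6-fold higher number from compound 1 to compound 4 (0.21 log units; within the scatter) as its step. Among the compounds shown here, at this place, on a six-membered aromatic ring of carbon only, part of a fused system of two rings, meta to a fused ring and para to a fused ring, the added methoxy therefore leaves the two compounds unordered, and the earlier compounds could not show this for the methoxy alone. No measurement at hand explains the size of this step or links it to any property of the group.

The compounds shown hold only hydrogen and methoxy at this place, so it remains open whether a hydroxyl, a fluorine, an amine, a carboxylic acid or a longer alkoxy chain there would give a step beyond the scatter. As far as these compounds go, this single step also comes from one background, the core of compound 1 with its phenyl group and methoxy on the shared core, and it remains open whether the same change gives a step of similar size on other backgrounds.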